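The source may report more compounds than this note shows. Statements on the series, on what has been measured and on what is new or still open speak of the compounds shown alone.

Measured compounds:
compound 1 `ClCc1ccccc1Cn1cnc2c(Cl)nc(Cl)nc21` — 1470 nM
compound 2 `ClCc1ccccc1Cn1cnc2c(Cl)ncnc21` — 16600 nM
compound 3 `ClCc1cccc(Cn2cnc3ncnc(Cl)c32)c1` — 1860 nM

All three were run in a functional assay on KM12 cells (Homo sapiens) for cytotoxicity, read by sulforhodamine B assay, with a stated time of 48 h; on this read-out lower numbers stand for stronger inhibition of growth and higher numbers for weaker inhibition of growth. Among the compounds with values here, the one single-point step in the set is chloro in place of hydrogen on an aromatic carbon, which gave an 11-fold lower number from compound 2 to compound 1 (1.05 log units; beyond the scatter). Compound 3 shares its atoms with compound 2, but the difference between the two cores is not broken down here; compound 3 sits within the scatter of compound 1 and well apart from compound 2.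

Compound 4 `ClCc1cccc(Cn2cnc3nc(Cl)nc(Cl)c32)c1` has not been measured. It differs from compound 3 by chloro in place of hydrogen on an aromatic carbon, the same change that separates compound 2 from compound 1, at a place described in identical words. Within the data shown here, the step expected for compound 4 is a 9.3-fold lower number from compound 3 to compound 4 (0.97 log units; beyond the scatter), resting on an 11-fold lower number from compound 2 to compound 1 (1.05 log units; beyond the scatter) as the only precedent. Compound 4 is therefore estimated at 200 nM, with a range from 80 nM to 500 nM.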

Compound 4, concentration for 50% growth inhibition: 16600 nM
Compound 4: the middle estimate sits 83-fold (1.92 log units) below what was measured; the measured number lies above the stated range.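

In this assay, within the data shown here, chloro in place of hydrogen on an aromatic carbon gave an 8.9-fold higher number from compound 3 to compound 4 (0.95 log units; beyond the scatter), so the change kept neither its direction nor its size from one core to the other: the same change on two cores in this assay, an 11-fold lower number (1.05 log units; beyond the scatter) from compound 2 to compound 1 and an 8.9-fold higher number (0.95 log units; beyond the scatter) from compound 3 to compound 4, 100-fold (2.00 log units) apart, beyond the scatter of two such steps With a single pair on each core, this shows only that the step cannot be carried across these two cores. It does not show which difference in the cores sets the direction, or how the change would behave on any other core.

The compounds shown leave open whether an amine or a methoxy group in place of this chloro would split the two cores in the same way. They also leave open whether a methyl group in place of the chloromethyl group would keep that split.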